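A few compounds are considered here, and "the series" means these few. Any claim that something is new, unique, unknown or untested is made for them only; others in the source may bear on it.

Measured so far:
compound 1, `CC1CCN(C2CCN(S(=O)(=O)c3cccc(-c4ccc5ccccc5c4)c3)CC2)CC1`: 2 nM
compound 2, `CC1CCCN(C2CCN(S(=O)(=O)c3ccc(OC(F)F)cc3)CC2)C1`: 105 nM

Both were read in a functional assay on DLD-1 cells (Homo sapiens) for antiproliferative activity, read by CellTiter-Glo, with a stated time of 72 h; on this read-out lower numbers stand for stronger inhibition and higher numbers for weaker inhibition. Compound 1 holds the lowest number of the two; compound 2 gives a higher number, a gap beyond the scatter. Compound 3, `Cc1cc(C)cc(-c2cccc(S(=O)(=O)N3CCC(N4CCC(C)CC4)CC3)c2)c1`, awaits measurement. It differs from compound 1 by 3,5-dimethylphenyl in place of naphthalen-2-yl on an aromatic carbon, on an aromatic carbon meta to a large group. One six-membered aromatic ring of carbon only stays where two stood, so a modest rise in number, not beyond a small step, is expected. Compound 3 is estimated at 5 nM (range 1.5 nM to 20 nM). The expected step is a 2.5-fold higher number from compound 1 to compound 3 (0.40 log units; beyond the scatter).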

Compound 3, half-maximal inhibitory concentration: 41 nM
Compound 3: middle estimate off by 8.2-fold (0.91 log units), on the low side, and the stated range ends below it.
By their numbers in this assay, from the lowest: compound 1; then compound 3; then compound 2.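

In this assay the change from naphthalen-2-yl to 3,5-dimethylphenyl on this aromatic carbon gives a 21-fold higher number from compound 1 to compound 3 (1.31 log units; beyond the scatter) and is a large step. The position therefore separates these two carbon-only aryl groups sharply, and the one with a single aromatic ring carries the higher number. Nothing measured here bears on the reason for the step.

The compounds shown do not separate loss of the second ring from the presence of the two methyl groups. Unsubstituted phenyl or quinolin-3-yl at this carbon remains open.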